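Shifting the nitro group around the aromatic ring

This account rests on a few compounds, and the source may have more. Where it says the series, first, only, none or still open, it means among the compounds named here.

The compounds here share one core, carrying a long chain amide, a hydroxymethyl group and an imine linked to an aromatic ring, and were tested in an ADME assay on HEK293 cells (Homo sapiens) for cytotoxicity; a lower number here means a stronger inhibitor, a higher number a weaker inhibitor. Among the compounds with values here, compound 1 `CCCCCCCCCCCCCCNC(=O)[C@H](CO)/N=C/c1ccc([N+](=O)[O-])cc1` gives 49500 nM in this assay, the lower of the two numbers measured so far. Compound 2 `CCCCCCCCCCCCCCNC(=O)[C@H](CO)/N=C/c1ccc(O)cc1` gives 71700 nM in this assay, with hydroxy in place of nitro on an aromatic carbon; the step of a 1.4-fold higher number from compound 1 to compound 2 (0.16 log units; within the scatter) lies within the scatter, so the two values cannot be told apart.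

Compound 3 `CCCCCCCCCCCCCCNC(=O)[C@H](CO)/N=C/c1ccccc1[N+](=O)[O-]` has not yet been measured in this assay. It differs from compound 1 as follows (2-nitrophenyl in place of 4-nitrophenyl on a carbon with a double bond to nitrogen). Within the data shown here, no measured step bears on this change: the one step on record alters the group itself rather than where on the ring it sits, and that step stayed within the scatter. With nothing to point either way, compound 3 is expected to stay close to compound 1, a step of a 1.0-fold higher number from compound 1 to compound 3 (0.00 log units; within the scatter) in this assay. The estimate for compound 3 is therefore 50000 nM, with a range from 20000 nM to 125000 nM.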

Compound 3, half-maximal inhibitory concentration: 82600 nM
Compound 3: middle estimate off by 1.7-fold (0.22 log units), on the low side; low and high end bracket the measured number.
By their numbers in this assay, from the lowest: compounds 1, 2 and 3 (each within the scatter of the next).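

In this assay, 2-nitrophenyl in place of 4-nitrophenyl on the carbon with a double bond to nitrogen gives a 1.7-fold higher number from compound 1 to compound 3 (0.22 log units; within the scatter). Within the data shown here, this is the first reading on where the nitro group sits rather than on which group is present, and at this scatter the two placements cannot be told apart. The comparison of 2-nitrophenyl with 4-hydroxyphenyl at the same place, a 1.2-fold higher number from compound 2 to compound 3 (0.06 log units; within the scatter), also stays within the scatter, so neither the group nor its placement separates any of the three compounds in this small set, and no measurement at hand offers an explanation for these numbers.

From the compounds shown here alone, it remains open whether an amine or a carboxylic acid on the aromatic ring would give a step beyond the scatter. The long chain amide, the hydroxymethyl group and the imine are the same in all three compounds, so it is also unknown how a shorter chain or an amine in place of the imine would read in this assay.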